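Swapping one amide group on compound 2

The compounds below may be only part of what the source reports. "The series", "measured", "known", "first", "only" and "open" are said of these compounds alone.

Measured so far in an ADME assay on MT4 cells (Homo sapiens) for cytotoxicity, read by MTT assay; on this read-out lower numbers stand for higher toxicity in this test and higher numbers for lower toxicity in this test:
- compound 1 `Cc1cc(C)cc(S(=O)(=O)c2c(C(=O)NCc3cccc(F)c3F)[nH]c3ccc(Cl)cc23)c1` gives > 51100 nM as a limit
- compound 2 `Cc1cc(C)cc(S(=O)(=O)c2c(C(=O)NC(C)C(=O)NC(C)c3ccccc3)[nH]c3ccc(Cl)cc23)c1` gives 21700 nM as a number

For the measured compounds named here, compound 2 holds the only true number so far. For compound 1 the reading > 51100 nM is a limit of the assay and not a number.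

The next compound is compound 3 `Cc1cc(C)cc(S(=O)(=O)c2c(C(=O)NC(C)C(=O)NCc3ccncn3)[nH]c3ccc(Cl)cc23)c1`, which is still unmeasured. It carries (pyrimidin-4-yl)methyl in place of 1-phenylethyl on an amide-type nitrogen and otherwise matches compound 2.

Going by the values given here, no measured pair shows what this swap does, so the expectation is loose. The expected step of a 1.6-fold higher number from compound 2 to compound 3 (0.21 log units; within the scatter) is a modest rise, which would mean lower toxicity in this assay and could reach the limit of the assay. Compound 3 is estimated at 35000 nM in this test. The expected range for compound 3 runs from 15000 nM to 80000 nM in this test.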

Compound 3, half-maximal cytotoxic concentration: 28100 nM
Beside the measured number, compound 3's estimate is 1.2-fold (0.10 log units) above it; low and high end bracket the measured number.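

In this assay, putting (pyrimidin-4-yl)methyl in place of 1-phenylethyl on this amide-type nitrogen gives a 1.3-fold higher number from compound 2 to compound 3 (0.11 log units; within the scatter), so exchanging a ring of carbon only for one with 2 hetero atoms leaves the reading within the usual scatter. The larger exchange of the whole group on that nitrogen gives an at least 1.8-fold lower number from compound 1 to compound 3 (0.25 log units; that floor lies within the scatter), and this is only a floor, so the true size of the step cannot be read. The reading for compound 1 is a limit of the assay and not a number: the limit of > 51100 nM in this assay, at which 1 of the 3 values shown sits.

Still open, on these data alone, is whether any group at this place can move the reading beyond the scatter. A carboxylic acid or a simple amine on the chain in place of (pyrimidin-4-yl)methyl would be one way to probe this, and the compounds shown say nothing about either.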